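Compound 4: phenyl in place of cyclohexyl

The source may hold more compounds than are shown below. What is called first, only, known or untested is meant among the compounds shown, and "the series" means these compounds.

Three compounds have numbers in a functional assay on brain (Rattus norvegicus, strain Wistar) for inhibition (on this read-out lower numbers stand for stronger inhibition and higher numbers for weaker inhibition), so far: compound 1 (`Cc1[nH]c(=O)n(C)c1-c1ccc(CC(C)C)cc1`) at 7800 nM and compound 2 (`CCCCCCOc1ccc(-c2c(C)[nH]c(=O)n2C)cc1`) at 7300 nM and compound 3 (`Cc1[nH]c(=O)n(C)c1-c1ccc(C2CCCCC2)cc1`) at 10000 nM on the same read-out. Compound 3 therefore sits level with the other two, with no gap beyond the scatter.

The next step leads to compound 4 (`Cc1[nH]c(=O)n(C)c1-c1ccc(-c2ccccc2)cc1`), with phenyl in place of cyclohexyl on an aromatic carbon. Three groups have already been compared at this place, and each step stayed within the scatter: isobutyl to hexyloxy (a 1.1-fold lower number from compound 1 to compound 2 (0.03 log units; within the scatter)), isobutyl to cyclohexyl (a 1.3-fold higher number from compound 1 to compound 3 (0.11 log units; within the scatter)) and hexyloxy to cyclohexyl (a 1.4-fold higher number from compound 2 to compound 3 (0.14 log units; within the scatter)). For the measured compounds named here, no measured compound carries phenyl there, so this read-across is limited.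

On these steps, no change beyond the scatter is expected in this assay and the expected step is small (a 1.3-fold lower number from compound 3 to compound 4 (0.10 log units; within the scatter)) in size. For compound 4 the estimated value is 8000 nM with an expected range of 3500 nM to 20000 nM for this number.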

Compound 4, half-maximal inhibitory concentration: 6300 nM
Beside the measured number, compound 4's estimate is 1.3-fold (0.10 log units) above it; measured number inside the range.
By their numbers in this assay, from the lowest: compounds 4, 2, 1 and 3 (each within the scatter of the next).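

In this assay, phenyl in place of cyclohexyl on an aromatic carbon stays within the scatter (a 1.6-fold lower number from compound 3 to compound 4 (0.20 log units; within the scatter)), so at this place an aromatic ring and a non-aromatic ring are not told apart. Phenyl is also within the scatter of the two open-chain groups (a 1.2-fold lower number from compound 2 to compound 4 (0.06 log units; within the scatter) against hexyloxy; a 1.2-fold lower number from compound 1 to compound 4 (0.09 log units; within the scatter) against isobutyl), which leaves all four groups seen here level with one another on this read-out. No supporting data bear on this flat result.

On these data alone, it remains open whether any group at this place can move the number beyond the scatter, for example an amine, a carboxylic acid or a hydroxyl group. As far as these compounds go, whether changes elsewhere on the shared core would do so also remains open.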